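A few compounds are considered here, and "the series" means these few. Any claim that something is new, unique, unknown or untested is made for them only; others in the source may bear on it.

Measured in a functional assay on MCF7 cells (Homo sapiens) for antiproliferative activity, read by sulforhodamine B assay, with a stated time of 48 h; a lower number here means a stronger inhibitor, a higher number a weaker inhibitor:
- Compound 1 `COc1ccc(C(=O)/C=C/c2ccccc2-c2ccc(F)cc2)cc1`: 8800 nM
- Compound 2 `COc1ccc(C(=O)/C=C/c2ccccc2-c2ccc(F)nc2)cc1`: 13000 nM

Only these two numbers are available, and they do not separate: the measured change is a 1.5-fold higher number from compound 1 to compound 2 (0.17 log units; within the scatter). Among the measured compounds shown here, compound 1 therefore cannot be ranked apart from compound 2, its only neighbour. That step placed 6-fluoropyridin-3-yl in place of 4-fluorophenyl on an aromatic carbon.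

Compound 3 `COc1ccc(C(=O)/C=C/c2ccccc2-c2ccc(F)cc2)cc1O` keeps the core of compound 1 and differs in a single place: hydroxy in place of hydrogen on an aromatic carbon. The new hydroxy stands ortho to a methoxy group and meta to a large group. For the measured compounds named here, no measured compound carries a hydroxy, and the one measured step concerns a different part of the molecule. It offers only indirect guidance, showing that one small edit to this core stayed within the scatter. With no evidence for a direction, no shift beyond the scatter is expected in this assay, though the uncertainty is wide. The estimated change is a 1.3-fold lower number from compound 1 to compound 3 (0.10 log units; within the scatter). Compound 3 is expected to give about 7000 nM, with an estimated range of 2000 nM to 20000 nM.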

Compound 3, half-maximal inhibitory concentration: 560 nM
The estimate for compound 3 lay 13-fold (1.10 log units) above the measured number; the measured number lies below the stated range.
By their numbers in this assay, from the lowest: compound 3; then compounds 1 and 2 (each within the scatter of the next).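

In this assay the hydroxy in place of hydrogen on this aromatic carbon, ortho to a methoxy group and meta to a large group, gives a 16-fold lower number from compound 1 to compound 3 (1.20 log units; beyond the scatter) and so stands as a large change from one added oxygen atom. Among the compounds shown here, the earlier step, a 1.5-fold higher number from compound 1 to compound 2 (0.17 log units; within the scatter), changed a different part of the molecule and did not separate its two compounds, so this aromatic carbon is the first place on the shared core where a small edit is seen to move the number clearly. No available measurement explains why this one hydroxy has an effect of this size.

The compounds shown leave open whether the gain belongs to the hydroxy itself or whether another small group on the same carbon, such as an amine or a single fluorine atom, would move the number in the same way. For the compounds shown here, they also leave open whether the hydroxy would bring a similar change when combined with the 6-fluoropyridin-3-yl group of compound 2, since the effect is seen on only one compound pair.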